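The source may hold more compounds than are shown below. What is called first, only, known or untested is meant among the compounds shown, and "the series" means these compounds.

Measured compounds:
compound 1 `Cc1occc1-c1nnc(SCC(=O)Nc2ccc(F)c(Cl)c2)n1Cc1ccco1`: 39.8 nM
compound 2 `Cc1occc1-c1nnc(SCC(=O)Nc2cccc(Cl)c2)n1Cc1ccco1`: 63.1 nM

In a functional assay on CHO cells for antagonist activity at Orexin receptor type 2 (Homo sapiens), read by FLIPR and calcium flux (a higher number here means a weaker inhibitor, a lower number a stronger inhibitor), compound 1 gives 39.8 nM, the lowest of the two numbers, although compound 2 at 63.1 nM lies within the scatter of it, as the step of a 1.6-fold higher number from compound 1 to compound 2 (0.20 log units; within the scatter) shows. Compound 3 `CC(=O)c1ccc(NC(=O)CSc2nnc(-c3ccoc3C)n2Cc2ccco2)cc1` differs from compound 1 by 4-acetylphenyl in place of 3-chloro-4-fluorophenyl on an amide-type nitrogen. Within the data shown here, no measured step bears directly on this change: the single step in hand, hydrogen in place of fluoro on an aromatic carbon, is a far smaller alteration than exchanging the whole 3-chloro-4-fluorophenyl for 4-acetylphenyl, and it stayed within the scatter. With so little to go on, a moderate weakening is expected rather than a large one, and compound 3 is estimated at 90 nM in this assay, between 25 nM and 320 nM, the expected step being a 2.3-fold higher number from compound 1 to compound 3 (0.35 log units; beyond the scatter).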

Compound 3, inhibition constant: 31.6 nM
Compound 3: middle estimate off by 2.8-fold (0.45 log units), on the high side, within the range that was stated.
By their numbers in this assay, from the lowest: compounds 3, 1 and 2 (each within the scatter of the next).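

Compound 3 carries neither chlorine nor fluorine on its aromatic ring, yet exchanging the whole aryl group on the amide-type nitrogen gives a 1.3-fold lower number from compound 1 to compound 3 (0.10 log units; within the scatter) and a 2.0-fold lower number from compound 2 to compound 3 (0.30 log units; within the scatter) in this assay. The earlier step showed only that the fluoro could give way to hydrogen; these steps show that the chloro is also dispensable here, and that this position accepts 4-acetylphenyl, with its added hydrogen-bond acceptor, without leaving the scatter. Nothing measured here offers an explanation for this result.

Going by these compounds, it remains open whether the acetyl group itself contributes anything, or whether plain phenyl on this nitrogen would read the same. On these data alone, how an amine, a carboxylic acid or a saturated ring such as cyclohexyl would fare at this place also remains open.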